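Swapping a pyrimidine for a pyridine on a piperazine

The source may hold more compounds than are shown below. What is called first, only, known or untested is meant among the compounds shown, and "the series" means these compounds.

Of the compounds shown here, two have been measured in an assay on isolated protein for inhibition of Substance-P receptor (Cavia porcellus), tested at 1 ug/mL; on this read-out higher numbers stand for more inhibition at the one concentration tested (going by the name of the read-out) and lower numbers for less inhibition. Compound 1, with the structure `COc1cc(C(=O)N2CO[C@](CCN3CCC4(CC3)CN(c3ccccc3)C(=O)O4)(c3ccc(Cl)c(Cl)c3)C2)cc(OC)c1OC`, gives 86% in this assay. Compound 2, with the structure `COc1cc(C(=O)N2CO[C@](CCN3CCN(c4ncccn4)CC3)(c3ccc(Cl)c(Cl)c3)C2)cc(OC)c1OC`, gives 100%, the highest of the two numbers; its nearest neighbour is compound 1, which lies lower by a gap beyond the usual scatter of repeated measurements.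

Compound 3, with the structure `COc1cc(C(=O)N2CO[C@](CCN3CCN(c4ccccn4)CC3)(c3ccc(Cl)c(Cl)c3)C2)cc(OC)c1OC`, has not yet been measured. It differs from compound 2 in one place: pyridin-2-yl in place of pyrimidin-2-yl on an amine nitrogen in a ring. The ring that leaves and the ring that enters are both six-membered aromatic rings on the amine nitrogen in the ring, and the change is small in size.

Within the data shown here, no measured pair shows this particular change, so its effect is unknown. Because compound 2 already reaches 100%, there is no room for a rise, and a small change of this kind is expected to cost little. The step of a number 8 percentage points lower from compound 2 to compound 3 (within the scatter) is expected to be small, within the scatter or a slight fall. Compound 3 is therefore estimated at 92%, with a range from 75% to 100%.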

Compound 3, a percentage reported as inhibition, at one concentration (the size of the read-out at that concentration, not a potency): 100%
Compound 3: middle estimate off by 8 percentage points, on the low side; the measured number falls inside the stated range.
By their numbers in this assay, from the lowest: compound 1; then compounds 2 and 3 (each within the scatter of the next).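

In this assay, replacing the pyrimidin-2-yl ring on the piperazine with pyridin-2-yl gives no change at the digits printed from compound 2 to compound 3 (within the scatter). At this place on the amine nitrogen, the ring can therefore go from two hetero atoms and two hydrogen-bond acceptors to one of each with no visible loss at the single concentration tested, although both numbers sit at the top of the scale, so a real difference in potency between the two compounds could stay hidden. No measurement here speaks to why the two rings give the same reading.

Going by these compounds, whether compound 2 and compound 3 would still match at a lower concentration, where inhibition is no longer complete, remains open. It is also unknown how much change this position accepts: a benzyl group, a thiazol-2-yl ring or a simple methyl group on the same nitrogen could show whether an aromatic ring with a ring nitrogen matters here at all.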